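The source may hold more compounds than are shown below. What is called first, only, known or untested is meant among the compounds shown, and "the series" means these compounds.

Compound 1, with the structure `COc1cc(NC(=O)Nc2ccccc2)cc(OC)c1OC`, stands without a number in a functional assay on ONS-76 cells (Homo sapiens) for cytotoxicity, read by MTT assay, with a stated time of 72 h; a higher number here means a weaker inhibitor, a lower number a stronger inhibitor: compound 1 gives there "not determined" (no result reported), so there is no single value for it. Of the two other compounds with the shared core, compound 2, `COc1cc(NC(=O)Nc2ccc3c(ccn3C)c2)cc(OC)c1OC`, gives in this assay >= 125000 nM, which is a limit of the assay and not a number. Compound 3, `COc1cc(NC(=O)c2cccc([N+](=O)[O-])c2)cc(OC)c1OC`, gives in this assay >= 125000 nM, again a limit rather than a measured figure. Both therefore rest at the limit of >= 125000 nM in this assay, at which 2 of the 3 values shown sit, and compound 1 has nothing of its own to set beside them.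

Compound 4, `COc1ccc(NC(=O)Nc2cc(OC)c(OC)c(OC)c2)cc1`, differs from compound 1 in one place: methoxy in place of hydrogen on an aromatic carbon. Going by the values given here, no measured step connects the two, so the size of the change in this assay cannot be read from the data. With both measured companions sitting at the limit, the expectation for this step is no shift beyond the usual scatter, in either direction, and a weak result. Compound 4 is thus estimated to show 100000 nM in this assay, in a range from 30000 nM to 300000 nM, with a real chance that only a limit is reported.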

Compound 4, half-maximal inhibitory concentration: 12900 nM
Compound 4: the middle estimate sits 7.8-fold (0.89 log units) above what was measured, outside the stated range (below it).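

No new step can be read: compound 1 has no value of its own in this assay, so the difference from compound 1 to compound 4 has no measurable size. The compounds shown leave open how far methoxy in place of hydrogen moves the result, and the other values offer only a limit for comparison: the limit of >= 125000 nM in this assay, at which 2 of the 4 values shown sit.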